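The compounds below may be only part of what the source reports. "The series", "measured", "known", "first", "only" and "open" are said of these compounds alone.

Working notes on the series in an ADME assay on A549 cells (Homo sapiens) for cytotoxicity, read by resazurin assay, with a stated time of 48 h; a lower number here means that less compound is tolerated, a higher number that more compound is tolerated: compound 1 `CCNc1ccc(NC(=O)c2cc(Cl)ccc2O)c(Cl)c1` gives 30200 nM, compound 2 `O=C(Nc1ccc(NCc2ccncc2)cc1Cl)c1cc(Cl)ccc1O` gives 65300 nM, and compound 3 `O=C(Nc1ccc(NCc2ccc(O)nc2)cc1Cl)c1cc(Cl)ccc1O` gives 98500 nM. Compound 3 thus shares the high end of these numbers with compound 2, and both stand clear of compound 1, as shown by a 2.2-fold higher number from compound 1 to compound 2 (0.33 log units; beyond the scatter) and a 3.3-fold higher number from compound 1 to compound 3 (0.51 log units; beyond the scatter). Compound 4 `O=C(Nc1ccc(NCc2ccc3cn[nH]c3c2)cc1Cl)c1cc(Cl)ccc1O` alters the same place, with 1H-indazol-6-yl in place of 6-hydroxypyridin-3-yl on a saturated chain carbon bound to a nitrogen on an aromatic ring. Within the data shown here, those two modest steps replace methyl, so the closer guide is the only exchange of one ring group for another, a 1.5-fold higher number from compound 2 to compound 3 (0.18 log units; within the scatter). In this assay, no change beyond the scatter is therefore expected, with a slight lean towards a lower number. The expected step is a 1.6-fold lower number from compound 3 to compound 4 (0.22 log units; within the scatter). For compound 4 the estimated value is 60000 nM, with an expected range of 25000 nM to 130000 nM.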

Compound 4, half-maximal cytotoxic concentration: 45300 nM
Beside the measured number, compound 4's estimate is 1.3-fold (0.12 log units) above it, and the stated range covers the measured number.
By their numbers in this assay, from the lowest: compounds 1, 4, 2 and 3 (each within the scatter of the next, the first and the last beyond it).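

In this assay, an exchange of one ring group for another at this position now gives a step beyond the scatter (a 2.2-fold lower number from compound 3 to compound 4 (0.34 log units; beyond the scatter)), whereas the earlier ring exchange stayed within it. The 1H-indazol-6-yl group stays within the scatter of both pyridin-4-yl (a 1.4-fold lower number from compound 2 to compound 4 (0.16 log units; within the scatter)) and methyl (a 1.5-fold higher number from compound 1 to compound 4 (0.18 log units; within the scatter)), so a ring group in place of methyl does not always give a step beyond the scatter. Nothing on hand accounts for these steps.

Open, on these data alone, is whether a piperidin-4-yl group or a 4-carboxyphenyl group at this place would fall with methyl or with 6-hydroxypyridin-3-yl.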